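Dropping the Chloro Group from a Weakly Active Hydrazone

The source may hold more compounds than are shown below. What is called first, only, known or untested is meant among the compounds shown, and "the series" means these compounds.

Two compounds built on the same shared core were tested in a functional assay on U-251 cells (Homo sapiens) for antiproliferative activity, read by sulforhodamine B assay, with a stated time of 48 h; on this read-out lower numbers stand for higher toxicity in this test and higher numbers for lower toxicity in this test. Compound 1 `COc1ccc(OC)c(/C=C/c2nnc(Nc3ccc(Cl)cc3)o2)c1` gives 47600 nM. Compound 2 `COc1ccc(OC)c(/C=C/C(=O)N/N=C/c2ccc(Cl)cc2)c1` is reported only as a limit of this assay, > 100000 nM, which is the limit of > 100000 nM in this assay, at which 1 of the 2 values shown sits, rather than a number. Among the measured compounds shown here, compound 1 is thus the only one of the pair with a numerical result on this read-out.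

Compound 3 `COc1ccc(OC)c(/C=C/C(=O)N/N=C/c2ccccc2)c1` has not yet been measured. It differs from compound 2 by hydrogen in place of chloro on an aromatic carbon, in words hydrogen in place of chloro on an aromatic carbon, para to a large group. For the measured compounds named here, no pair of measured compounds differs in exactly this way, so there is no measured step of this kind to lean on, and the weakly active starting point leaves little room for a visible change in either direction. The expected step from compound 2 to compound 3 is therefore none beyond the usual scatter, a number no higher from compound 2 to compound 3 (the limit leaves the size open). Compound 3 is expected to give about 100000 nM, most likely again returned only as a limit, with a plausible range from 50000 nM to 200000 nM.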

Compound 3, concentration lethal to 50% of the cells: > 100000 nM
Compound 3 was reported as a limit; the forecaster's own chance of this, stated with the estimate: 75%; the middle value lies on the limit itself.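

Compound 2 and compound 3 both stand at a limit of this assay rather than at a number, so no step can be read between them: the limit of > 100000 nM in this assay, at which 2 of the 3 values shown sit.

On these data alone, whether going from 4-chlorophenyl to phenyl changes the result at all stays open, and so does the actual number for either compound.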